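The source may hold more compounds than are shown below. What is called first, only, known or untested is meant among the compounds shown, and "the series" means these compounds.

In a functional assay on the whole organism with Mus musculus as the target (on this read-out lower numbers stand for an effect already at smaller amounts and higher numbers for an effect only at larger amounts of compound), two compounds have been measured so far. Compound 1 `Cc1ccccc1-c1ccc(N2CCC(O)CC2)nn1` gives 40 mg/kg. Compound 2 `O=C(OC1CCN(c2ccc(-c3ccccc3Cl)nn2)CC1)C1CC1` gives 92 mg/kg, the higher of the two numbers, and its gap to compound 1 lies beyond the usual scatter. Compound 3 `C/N=C(\S)OC1CCN(c2ccc(-c3ccccc3Cl)nn2)CC1` keeps the core of compound 2 and differs only in the group on an oxygen on a saturated carbon: a group of 4 heavy atoms (2 carbon, 1 nitrogen, 1 sulfur; no ring) in place of a group of 5 heavy atoms (4 carbon, 1 oxygen; one three-membered non-aromatic ring of carbon only), on an oxygen on a saturated carbon. Among the measured compounds shown here, no measured pair of compounds differing in one place shows what such a change does, so any expectation here is loose. For the measured compounds named here, the expected 1.3-fold lower number from compound 2 to compound 3 (0.12 log units; within the scatter) stays within the scatter and leans towards lower numbers, with compound 1 at 40 mg/kg as the only lower value known. In this assay compound 3 is estimated at 70 mg/kg, with an expected range from 30 mg/kg to 170 mg/kg.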

Compound 3, dose for half-maximal effect: 20 mg/kg
Beside the measured number, compound 3's estimate is 3.5-fold (0.54 log units) above it, outside the stated range (below it).
By their numbers in this assay, from the lowest: compounds 3 and 1 (each within the scatter of the next); then compound 2.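

In this assay the group on an oxygen on a saturated carbon proves able to shift the read-out: exchanging cyclopropylcarbonyl for the group of 4 heavy atoms gives a 4.6-fold lower number from compound 2 to compound 3 (0.66 log units; beyond the scatter) and is the only step shown that changes one place alone. This position therefore responds to what it carries, and the lower number comes with a group that has no ring and has a hydrogen-bond donor, which cyclopropylcarbonyl lacks. Nothing available explains the step.

On these data alone, whether the sulfur, the nitrogen or the methyl of the new group matters most stays open, as does what an acetyl group, a longer acyl chain or a urethane-type group with oxygen in place of sulfur would do on this oxygen. Also open, as far as these compounds go, is whether the same exchange would give a similar step on the core of compound 1.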